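The source may hold more compounds than are shown below. What is called first, only, known or untested is meant among the compounds shown, and "the series" means these compounds.

The measured compounds:
compound 1 `CC(=O)NCc1ccc(-c2c3ncn(CC4(O)CCN(Cc5ccc(-c6ccco6)cc5Cl)CC4)c(=O)c3nn2C)cc1`: 46.1 nM
compound 2 `Cn1nc2c(=O)n(CC3(O)CCN(Cc4ccc(-c5cncs5)cc4Cl)CC3)cnc2c1-c1ccc(CN)cc1`: 117 nM
compound 3 `Cn1nc2c(=O)n(CC3(O)CCN(Cc4ccc(-c5ccc[nH]5)cc4Cl)CC3)cnc2c1-c1ccc(CN)cc1`: 193 nM

In an assay on isolated protein for inhibition of ubiquitin carboxyl-terminal hydrolase 7 (Homo sapiens), with stated times of 30 min and 2 h (a lower number here means a stronger inhibitor, a higher number a weaker inhibitor), compound 1 gives the lowest of the three numbers, and both other values stand beyond the scatter above it, so compound 1 is the strongest inhibitor of this small set. Compound 4 `Cn1nc2c(=O)n(CC3(O)CCN(Cc4ccc(-c5ccco5)cc4Cl)CC3)cnc2c1-c1ccc(CNC(=O)C(F)(F)F)cc1` has not yet been measured; it differs from compound 1 in one place: trifluoromethyl in place of methyl on a carbonyl carbon. For the measured compounds named here, the only measured step, a 1.6-fold higher number from compound 2 to compound 3 (0.22 log units; within the scatter), concerns another part of the structure and gives no guide to the acetyl end. Compound 2 and compound 3 are related to compound 1 only through their values. With nothing that bears on this change, no step beyond the scatter is expected. Compound 4 is estimated at 55 nM, with a likely range from 25 nM to 130 nM. That expectation amounts to a 1.2-fold higher number from compound 1 to compound 4 (0.08 log units; within the scatter).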

Compound 4, half-maximal inhibitory concentration: 2060 nM
Beside the measured number, compound 4's estimate is 37-fold (1.57 log units) below it, outside the stated range (above it).
By their numbers in this assay, from the lowest: compound 1; then compounds 2 and 3 (each within the scatter of the next); then compound 4.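

In this assay, the acetyl end of compound 1 proves sensitive to change: replacing only the methyl on the carbonyl carbon with trifluoromethyl gives a 45-fold higher number from compound 1 to compound 4 (1.65 log units; beyond the scatter), a large loss of inhibition. For the compounds shown here, the earlier compounds gave no information about this position, so this is the first sign that a small change here can matter so much. Nothing measured here shows why this change has such an effect. The compounds shown leave open how ethyl or difluoromethyl on that carbonyl carbon would read, and so whether the loss is specific to trifluoromethyl.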